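Working notes: from compound 2 to compound 3

The compounds below may be only part of what the source reports. "The series", "measured", "known", "first", "only" and "open" are said of these compounds alone.

- compound 1 `O=C(c1ccc(F)c(O)c1)c1ccc2cc(O)ccc2n1` gives > 200000 nM as a limit of the assay
- compound 2 `Cc1cc(-c2ccc3ccc(C(=O)c4ccc(F)c(O)c4)nc3c2)ccc1O` gives 13000 nM as a measured number

Within the data shown here, in a physicochemical assay for solubility, in phosphate buffer, with a stated time of 24 h, at pH 7.4, tested at 200 uM (on this read-out lower numbers stand for lower solubility and higher numbers for higher solubility), compound 2 at 13000 nM holds the only actual number so far. Compound 3 `Nc1ccc2ccc(C(=O)c3ccc(F)c(O)c3)nc2c1` has amino in place of 4-hydroxy-3-methylphenyl on an aromatic carbon in the structure. Among the measured compounds shown here, no measured step covers this change. Compound 1, which also carries no 4-hydroxy-3-methylphenyl, reports only the limit > 200000 nM and this is the sole ground for expecting a rise in this assay here. The estimated 9.2-fold higher number from compound 2 to compound 3 (0.97 log units; beyond the scatter) is an expected rise beyond the usual scatter. For compound 3 the estimate is 120000 nM with an expected range from 40000 nM to 200000 nM in this assay here.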

Compound 3, solubility: > 200000 nM
Compound 3 was reported as a limit (the forecaster's own chance of this, stated with the estimate: 35%); at least 1.6-fold (0.22 log units) between middle value and limit.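

In this assay, among these compounds, amino in place of 4-hydroxy-3-methylphenyl on an aromatic carbon gives an at least 15-fold higher number from compound 2 to compound 3 (1.18 log units; beyond the scatter) and is the first step read at this position. Compound 3 gives > 200000 nM as a limit and not a number. The size of the step is therefore a lower bound only: the limit of > 200000 nM in this assay, at which 2 of the 3 values shown sit.

In this assay, on these data alone, it stays open where phenyl or morpholine would fall on this aromatic carbon. No order between compound 1 and compound 3 can be read, since both are limits.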